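Phenyl for Methyl on an Aromatic Nitrogen

A few compounds are considered here, and "the series" means these few. Any claim that something is new, unique, unknown or untested is made for them only; others in the source may bear on it.

Measured compounds:
compound 1 `CC(C)c1cc2c(-c3ccc(F)cc3)c(/C=C/[C@@H](O)C[C@@H](O)CC(=O)O)c(C(C)C)nc2s1`: -71.5%
compound 2 `Cc1nn(C)c2nc(C(C)C)c(/C=C/[C@@H](O)C[C@@H](O)CC(=O)O)c(-c3ccc(F)cc3)c12`: 41.1%

In an in vivo functional assay on the whole organism for inhibition of 3-hydroxy-3-methylglutaryl-coenzyme A reductase (Rattus norvegicus), at a dose of 0.2 mg/kg by the oral route (a lower number here means a weaker effect, a higher number a stronger effect of the compound at the dose given), compound 1 gives -71.5%, while compound 2 gives 41.1%. Compound 2 holds the highest of the two numbers; its nearest neighbour is compound 1, whose number sits lower by a gap that lies beyond the scatter. Compound 1 and compound 2 differ in more than one place, so that gap cannot be tied to any single change.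

Compound 3 `Cc1nn(-c2ccccc2)c2nc(C(C)C)c(/C=C/[C@@H](O)C[C@@H](O)CC(=O)O)c(-c3ccc(F)cc3)c12` differs from compound 2 in one place: phenyl in place of methyl on an aromatic nitrogen. Going by the values given here, no measured pair shows the effect of this change, so the expectation rests on compound 2 alone. The step of a number 6.1 percentage points lower from compound 2 to compound 3 (within the scatter) is expected to be none beyond the scatter, in either direction, with wide uncertainty. Compound 3 is therefore estimated at 35%, with a range from -25% to 75%.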

Compound 3, a percentage reported as inhibition, in the whole organism at one dose (the size of the read-out at that dose, not a potency): 3.3%
Estimate against measurement, compound 3: 31.7 percentage points above, within the range that was stated.
By their numbers in this assay, from the lowest: compound 1; then compound 3; then compound 2.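

In this assay the aromatic nitrogen of the five-membered ring proves sensitive to what it carries: phenyl in place of methyl brings a number 37.8 percentage points lower from compound 2 to compound 3 (beyond the scatter) and so a large loss of effect at the dose given. Going by these compounds alone, this is the first change that can be read on its own, as the earlier pair differed in more than one place, and it shows that methyl serves better than phenyl at this nitrogen. Nothing measured on these compounds accounts for the drop.

On these data alone, whether the loss comes with any group larger than methyl or only with an aromatic ring stays open, and ethyl or cyclohexyl on this nitrogen would separate the two readings. Also open, as far as these compounds go, is whether the methyl group two ring bonds away alters what phenyl does here.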